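This account rests on a few compounds, and the source may have more. Where it says the series, first, only, none or still open, it means among the compounds named here.

Measured compounds:
- Compound 1, `O=C(CN1CN(c2ccccc2)C2(CCN(C(=O)c3ccc(C4CCCCC4)cc3)CC2)C1=O)NCCO`: 2000 nM
- Compound 2, `O=C(CN1CN(c2ccccc2)C2(CCN(C(=O)c3ccc(C4CCCCC4)cc3)CC2)C1=O)N1CCC(CO)CC1`: 1100 nM
- Compound 3, `CC(C)(C)OC(=O)NCNC(=O)CN1CN(c2ccccc2)C2(CCN(C(=O)c3ccc(C4CCCCC4)cc3)CC2)C1=O`: 1700 nM

All three share one core and differ only in the group carried on the amide beyond the carbonyl. In an assay on HEK293 cells for displacement of a labelled ligand from NPC1-like intracellular cholesterol transporter 1 (Homo sapiens) (a higher number here means a weaker inhibitor, a lower number a stronger inhibitor), compound 3 stands second highest of the three numbers. Its nearest neighbour is compound 1, whose number is higher by a 1.2-fold lower number from compound 1 to compound 3 (0.07 log units; within the scatter) when read the other way; compound 2 is furthest, with a 1.5-fold higher number from compound 2 to compound 3 (0.19 log units; within the scatter) separating them. Both steps are within the scatter, so the three compounds cannot be told apart on these numbers.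

Compound 4, `CC(C)(C)OC(=O)NCCNC(=O)CN1CN(c2ccccc2)C2(CCN(C(=O)c3ccc(C4CCCCC4)cc3)CC2)C1=O`, is a fresh variation on this same amide arm. The change from compound 3 is ((tert-butoxycarbonyl)amino)methyl in place of (tert-butoxycarbonyl)amino on a saturated chain carbon bound to an amide-type nitrogen; cut one bond further out, it reads ((tert-butoxycarbonyl)amino)methyl to 2-((tert-butoxycarbonyl)amino)ethyl. Within the data shown here, no measured step lengthens this chain. Among the measured compounds shown here, the steps that bear on the arm, a 1.2-fold lower number from compound 1 to compound 3 (0.07 log units; within the scatter) and a 1.8-fold lower number from compound 1 to compound 2 (0.26 log units; within the scatter), both exchange what the amide nitrogen carries and both stay within the scatter. The expectation for compound 4 in this assay is therefore a step of no change at the digits printed from compound 3 to compound 4 (within the scatter), not beyond the scatter. Compound 4 is estimated at 1700 nM, with a range from 800 nM to 3600 nM.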

Compound 4, half-maximal inhibitory concentration: 5500 nM
The estimate for compound 4 lay 3.2-fold (0.51 log units) below the measured number; the measured number lies above the stated range.
By their numbers in this assay, from the lowest: compounds 2, 3 and 1 (each within the scatter of the next); then compound 4.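

In this assay, the amide arm now shows its first steps beyond the scatter: moving from ((tert-butoxycarbonyl)amino)methyl to 2-((tert-butoxycarbonyl)amino)ethyl gives a 3.2-fold higher number from compound 3 to compound 4 (0.51 log units; beyond the scatter), so this position does respond to the length of the chain that carries the tert-butoxycarbonyl group. Exchanging the end group matters as well, since putting (tert-butoxycarbonyl)amino in place of hydroxy on the same saturated chain gives a 2.8-fold higher number from compound 1 to compound 4 (0.44 log units; beyond the scatter), and the step from the 4-(hydroxymethyl)piperidin-1-yl amide is a 5.0-fold higher number from compound 2 to compound 4 (0.70 log units; beyond the scatter), whereas compounds 1, 2 and 3 could not be told apart. No accompanying measurement explains why compound 4 is the weakest of the four.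

From the compounds shown here alone, it remains open whether the loss follows the chain length alone or needs the bulky carbamate at its end, and a longer chain ending in the same group would test the first of these. A free amine or a carboxylic acid at the end of the ethyl chain would show how far the end group alone can move the number.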